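The source may report more compounds than this note shows. Statements on the series, on what has been measured and on what is new or still open speak of the compounds shown alone.

Values in a functional assay on MCF7 cells (Homo sapiens) for antiproliferative activity, with a stated time of 5 days; a higher number here means a weaker inhibitor, a lower number a stronger inhibitor:
- compound 1 `CCCCc1ccc2[nH]c(-c3ccc(OC)cc3)c(C=O)c2c1`: 22 nM
- compound 2 `CCCCc1ccc2[nH]c(-c3ccc(C)cc3)c(C=O)c2c1`: 54 nM
- compound 3 `CCCCc1ccc2[nH]c(-c3ccc(CC)cc3)c(C=O)c2c1`: 58 nM

In this assay, compound 3 gives 58 nM. That places it level with compound 2, since the data show a 1.1-fold higher number from compound 2 to compound 3 (0.03 log units; within the scatter). Both sit on the weaker side of compound 1, and the two steps away from the methoxy group are a 2.5-fold higher number from compound 1 to compound 2 (0.39 log units; beyond the scatter) and a 2.6-fold higher number from compound 1 to compound 3 (0.42 log units; beyond the scatter).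

The next compound is compound 4 `CCCCc1ccc2[nH]c(-c3ccc(F)cc3)c(C=O)c2c1`, which carries fluoro in place of ethyl on an aromatic carbon, para to a large group: fluoro in place of ethyl on an aromatic carbon.

All three measured steps change the group at this same place, so they are the relevant guide. Among the measured compounds shown here, none of the measured compounds carries a fluoro group, however, so they can only suggest a likely size of step. Two of these steps were modest and one stayed within the scatter. A large jump therefore seems unlikely, and a small move towards a higher number, possibly lost in the scatter, is the most reasonable expectation.

The expected change is a 1.3-fold higher number from compound 3 to compound 4 (0.11 log units; within the scatter). Compound 4 is estimated at 75 nM, with an expected range from 25 nM to 220 nM.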

Compound 4, half-maximal inhibitory concentration: 200 nM
Estimate against measurement, compound 4: 2.7-fold (0.43 log units) below; the range from low to high includes it.
By their numbers in this assay, from the lowest: compound 1; then compounds 2 and 3 (each within the scatter of the next); then compound 4.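

In this assay the group on this aromatic carbon, para to a large group, matters more than the near-identical methyl and ethyl compounds could show: fluoro in place of ethyl gives a 3.4-fold higher number from compound 3 to compound 4 (0.54 log units; beyond the scatter) and fluoro in place of methyl gives a 3.7-fold higher number from compound 2 to compound 4 (0.57 log units; beyond the scatter) at the same place. The step from the methoxy compound is the widest of the three, with fluoro in place of methoxy giving a 9.1-fold higher number from compound 1 to compound 4 (0.96 log units; beyond the scatter) and so setting the two ends of this small series, with compound 1 the strongest and compound 4 the weakest inhibitor of the four. The information available offers no measurement that explains why fluoro behaves this way here.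

The compounds shown leave open where other groups at this place would fall, such as a hydroxyl, an amine, chloro or a longer chain, and whether any would match or pass the methoxy group of compound 1. Going by these compounds, all four compounds also share the butyl chain and the carbonyl, so it remains open whether this order of groups would hold if either of those changed.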